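A few compounds are considered here, and "the series" means these few. Any claim that something is new, unique, unknown or untested is made for them only; others in the source may bear on it.

Compound 1 `CC(=O)OC[C@H]1O[C@@H](n2cc(CN3C(=O)/C(=C\c4ccccc4)c4ccccc43)nn2)[C@H](OC(C)=O)[C@@H](OC(C)=O)[C@@H]1OC(C)=O` gives 24300 nM in a functional assay on MCF7 cells (Homo sapiens) for cytotoxicity, read by sulforhodamine B assay, with a stated time of 48 h; a higher number here means a weaker inhibitor, a lower number a stronger inhibitor. For compound 2 `CC(=O)OC[C@H]1O[C@@H](n2cc(CN3C(=O)/C(=C\c4ccc(C)cc4)c4ccccc43)nn2)[C@H](OC(C)=O)[C@@H](OC(C)=O)[C@@H]1OC(C)=O`, this assay reports only a limit, > 100000 nM. Compound 2 therefore stands at the higher of the two numbers shown, since the change an at least 4.1-fold higher number from compound 1 to compound 2 (0.61 log units; beyond the scatter) was the one measured step, and its size rests on a limit (the limit of > 100000 nM in this assay, at which 1 of the 2 values shown sits). Compound 3 `COc1ccc(/C=C2\C(=O)N(Cc3cn([C@@H]4O[C@H](COC(C)=O)[C@@H](OC(C)=O)[C@H](OC(C)=O)[C@H]4OC(C)=O)nn3)c3ccccc32)cc1OC` differs from compound 2 by 3,4-dimethoxyphenyl in place of 4-methylphenyl on a double-bonded chain carbon bound to a double-bonded ring carbon. Among the measured compounds shown here, no measured step bears directly on this exchange. Compound 3 is expected to give about 70000 nM in this assay, between 15000 nM and 250000 nM. The step of an at least 1.4-fold lower number from compound 2 to compound 3 (0.15 log units; that floor lies within the scatter) is thus estimated to stay within the scatter.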

Compound 3, half-maximal inhibitory concentration: 23500 nM
Beside the measured number, compound 3's estimate is 3.0-fold (0.47 log units) above it, and the stated range covers the measured number.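

In this assay, 3,4-dimethoxyphenyl in place of 4-methylphenyl on the double-bonded chain carbon gives an at least 4.2-fold lower number from compound 2 to compound 3 (0.62 log units; beyond the scatter), and the size of that step rests on a limit: the limit of > 100000 nM in this assay, at which 1 of the 3 values shown sits.

Set against phenyl, the same group gives a 1.0-fold lower number from compound 1 to compound 3 (0.01 log units; within the scatter). A substituted phenyl here therefore need not weaken the compound, and compound 2 is the one that goes against that reading.

The compounds shown leave open whether 4-methoxyphenyl, 4-chlorophenyl or 4-aminophenyl in the same place would track compound 2 or compound 3.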